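Methyl in Place of Bromo on the Triazole Aryl Group

The compounds below may be only part of what the source reports. "The series", "measured", "known", "first", "only" and "open" are said of these compounds alone.

Compound 3 `C=C1C[C@]23C[C@@]1(O)CC[C@H]2c1ccc(O)c(C)c1[C@@H]3Cn1cc(-c2ccc(Br)cc2)nn1` is the phenol of this set. In a functional assay on SW480 cells (Homo sapiens) for cytotoxicity, read by MTT assay, with a stated time of 4 days (a higher number here means a weaker inhibitor, a lower number a stronger inhibitor), compound 3 gives > 20000 nM, which is a limit of the assay rather than a number. Compound 1 `C=C1C[C@]23C[C@@]1(O)CC[C@H]2c1ccc(OS(=O)(=O)c2ccc(C)cc2)c(C)c1[C@@H]3Cn1cc(-c2ccc(Br)cc2)nn1` carries a (4-methylphenyl)sulfonyl on an oxygen on an aromatic ring; in this assay compound 1 gives > 20000 nM, likewise a limit. Compound 2 `Cc1c(O)ccc2c1[C@H](Cn1cc(-c3ccccn3)nn1)[C@@]13CC(=O)[C@@](C)(CC[C@@H]21)C3` in this assay gives > 20000 nM, again a limit. Hence the step that the two limits leave unreadable from compound 1 to compound 3 cannot be sized, and the limit of > 20000 nM in this assay, at which 3 of the 3 values shown sit, is all the evidence available. Compound 4 `C=C1C[C@]23C[C@@]1(O)CC[C@H]2c1ccc(O)c(C)c1[C@@H]3Cn1cc(-c2ccc(C)cc2)nn1` differs from compound 3 by methyl in place of bromo on an aromatic carbon. Going by the values given here, no measured step bears on this change, so the expected step that the limit leaves unreadable from compound 3 to compound 4 is none beyond the scatter. Compound 4 is therefore expected to give 30000 nM, between 10000 nM and 100000 nM, most likely again as a limit.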

Compound 4, half-maximal inhibitory concentration: > 20000 nM
Compound 4: no number, only a limit; the forecaster's own chance of this, stated with the estimate: 85%; the middle value lies beyond the limit too.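

In this assay compound 4 gives > 20000 nM, a limit of the assay and not a number. The step from compound 3 to compound 4 therefore cannot be read. The compounds shown leave open whether bromo and methyl on the aryl group differ at all in this assay, and the only evidence is this: the limit of > 20000 nM in this assay, at which 4 of the 4 values shown sit.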